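The source may report more compounds than this note shows. Statements on the series, on what has been measured and on what is new or still open speak of the compounds shown alone.

Measured so far in an ADME assay on HOS cells (Homo sapiens) for cytotoxicity, read by luminescence and ATP content, with a stated time of 48 h; on this read-out higher numbers stand for lower toxicity in this test and lower numbers for higher toxicity in this test:
Compound 1 `Nc1c(C(=O)NCc2ccc(F)cc2F)c(=O)n(O)c2ncc(CCCC3CCCCC3)cc12`: 27400 nM
Compound 2 `Nc1c(C(=O)NCc2ccc(F)cc2F)c(=O)n(O)c2ncc(CCCOCCO)cc12`: > 250000 nM, a limit
Compound 3 `Nc1c(C(=O)NCc2ccc(F)cc2F)c(=O)n(O)c2ncc(CCC(=O)O)cc12`: > 250000 nM, a limit

Compound 3 sits at the limit of > 250000 nM in this assay, at which 2 of the 3 values shown sit, so no number is known for it. Compound 4 `CC(C)NC(=O)/C=C/c1cnc2c(c1)c(N)c(C(=O)NCc1ccc(F)cc1F)c(=O)n2O` carries 2-(isopropylcarbamoyl)ethenyl in place of 2-carboxyethyl on an aromatic carbon.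

Within the data shown here, two measured steps bear on this change, both beyond the scatter: an at least 9.1-fold higher number from compound 1 to compound 3 (0.96 log units; beyond the scatter) and an at least 9.1-fold higher number from compound 1 to compound 2 (0.96 log units; beyond the scatter). Neither involves the entering group, and a step that the two limits leave unreadable from compound 2 to compound 3. Among the measured compounds shown here, the only compound with a number is compound 1 at 27400 nM, and the group entering compound 4 has no ring, unlike the cyclohexyl of compound 1. In this assay a number somewhat lower than the limit of compound 3 is therefore expected, though another limit is quite possible. The expected step is an at least 2.0-fold lower number from compound 3 to compound 4 (0.31 log units; beyond the scatter). For compound 4 the estimated value is 120000 nM, with an expected range from 40000 nM to 250000 nM.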

Compound 4, half-maximal cytotoxic concentration: > 250000 nM
Compound 4: no number, only a limit; the forecaster's own chance of this, stated with the estimate: 40%; middle value at least 2.0-fold (0.31 log units) from the limit.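

On the aromatic carbon two atoms from the ring nitrogen, 2-(isopropylcarbamoyl)ethenyl gives an at least 9.1-fold higher number from compound 1 to compound 4 (0.96 log units; beyond the scatter), so in this assay a chain ending in neither carboxy nor hydroxy also shows less toxicity than 3-cyclohexylpropyl. The steps from compound 2 and from compound 3 to compound 4 cannot be read: all three values are limits and not numbers. Compound 1 thus remains the only compound with a number, and compound 4 joins the others at the top of the range: the limit of > 250000 nM in this assay, at which 3 of the 4 values shown sit.

As far as these compounds go, how compound 2, compound 3 and compound 4 rank among themselves stays open. From the compounds shown here alone, it is also open whether the cyclohexyl ring itself lowers the number, or whether a plain hexyl chain or a phenyl ring at the end of the propyl chain would do the same.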